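Lengthening the alkyl group on the shared core

A few compounds are considered here, and "the series" means these few. Any claim that something is new, unique, unknown or untested is made for them only; others in the source may bear on it.

Compound 1, `Cc1ccc(Oc2ccc(/C=N/n3c(C)nc4ccccc4c3=O)cc2)cc1`: 4.32
Compound 2, `Cc1nc2ccccc2c(=O)n1/N=C/c1ccc(Oc2ccc([N+](=O)[O-])cc2)cc1`: 4.01
Compound 3, `Cc1cc(Oc2ccc(/C=N/n3c(C)nc4ccccc4c3=O)cc2)ccc1Cl`: 4.41

Of the compounds shown here, three have been measured in a physicochemical assay for lipophilicity, in phosphate buffer, measured as octanol-water partition; a lower number here means a more polar compound, a higher number a more lipophilic compound. Compound 1 stands second highest of the three; compound 3 sits nearest, with a number 0.09 log units higher from compound 1 to compound 3 (within the scatter), and compound 2 sits furthest, with a number 0.31 log units lower from compound 1 to compound 2 (beyond the scatter). The third measured step, a number 0.40 log units higher from compound 2 to compound 3 (beyond the scatter), likewise concerns the aryl group on the ether oxygen.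

The step now followed goes from compound 1 to compound 4, `CCCc1nc2ccccc2c(=O)n1/N=C/c1ccc(Oc2ccc(C)cc2)cc1`. The change is ethyl in place of hydrogen on a saturated chain carbon bound to an aromatic carbon. Going by the values given here, none of the measured steps bears on this part of the structure: all three vary the aryl group on the ether oxygen and leave the shared core untouched, so no measured step speaks directly to what is expected here. What remains is the general behaviour of this kind of measurement, in which growing an alkyl chain on the core usually raises the partition coefficient, though by an amount that cannot be read from the three compounds above.

On that basis compound 4 is expected to give 5.1, within a range from 4.7 to 5.5, which corresponds to an estimated step of a number 0.78 log units higher from compound 1 to compound 4 (beyond the scatter).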

Compound 4, partition coefficient: 5.45
Estimate against measurement, compound 4: 0.35 log units below, and the stated range covers the measured number.
By their numbers in this assay, from the lowest: compound 2; then compounds 1 and 3 (each within the scatter of the next); then compound 4.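

In this assay, going by these compounds alone, ethyl in place of hydrogen on a saturated chain carbon bound to an aromatic carbon, a difference that also reads as methyl to propyl, gives a number 1.13 log units higher from compound 1 to compound 4 (beyond the scatter) and so shows for the first time that the number responds to a change on the shared core. That single change counts for more than any of the changes to the aryl group on the ether oxygen, where a number 0.31 log units lower from compound 1 to compound 2 (beyond the scatter) and a number 0.40 log units higher from compound 2 to compound 3 (beyond the scatter) are the steps that lie beyond the scatter and a number 0.09 log units higher from compound 1 to compound 3 (within the scatter) lies within it. Nothing among the data shown accounts for the size of the new step.

From the compounds shown here alone, whether a longer chain such as butyl, a branched group such as isopropyl or an amine at the end of the chain would carry the number further along the same line stays open, since a single chain length at this carbon gives no trend. Going by these compounds, it also stays open whether the same ethyl change would give a step of similar size alongside the 4-nitrophenyl group of compound 2 or the 4-chloro-3-methylphenyl group of compound 3.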